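Removing the Last Methyl from the Amine Nitrogen

The source may hold more compounds than are shown below. What is called first, only, known or untested is meant among the compounds shown, and "the series" means these compounds.

Measured so far in a functional assay for agonist activity at G protein-coupled receptor 88 (Homo sapiens), read by HTRF and cAMP accumulation; on this read-out higher numbers stand for an effect only at larger amounts of compound and lower numbers for an effect already at smaller amounts:
compound 1 `CC[C@H](C)[C@H](N)CN(C(=O)[C@@H]1C[C@H]1c1ccccc1)c1ccc(-c2ccc(NC(C)=O)cc2)cc1`: 5500 nM
compound 2 `CC[C@H](C)[C@H](N)CN(C(=O)[C@@H]1C[C@H]1c1ccccc1)c1ccc(-c2ccc(CN(C)C)cc2)cc1`: 460 nM
compound 3 `CC[C@H](C)[C@H](N)CN(C(=O)[C@@H]1C[C@H]1c1ccccc1)c1ccc(-c2ccc(CNC)cc2)cc1`: 6400 nM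

Compound 3 stands highest of the three numbers in this assay; the steps of a 1.2-fold higher number from compound 1 to compound 3 (0.07 log units; within the scatter) and a 14-fold higher number from compound 2 to compound 3 (1.14 log units; beyond the scatter) mark its position, the first within the scatter, the second well beyond it.

Compound 4 `CC[C@H](C)[C@H](N)CN(C(=O)[C@@H]1C[C@H]1c1ccccc1)c1ccc(-c2ccc(CN)cc2)cc1` differs from compound 3 by hydrogen in place of methyl on an amine nitrogen. The step that bears on it is a 14-fold higher number from compound 2 to compound 3 (1.14 log units; beyond the scatter), the same kind of change at the same nitrogen, and it was large; a 12-fold lower number from compound 1 to compound 2 (1.08 log units; beyond the scatter) shows the same pair from the other side. For the measured compounds named here, no measured compound shows whether a second such change continues in that direction. A further increase is expected, smaller than the earlier one: a 1.9-fold higher number from compound 3 to compound 4 (0.27 log units; within the scatter). Compound 4 is estimated at 12000 nM, with a range from 3000 nM to 40000 nM.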

Compound 4, half-maximal effective concentration: > 30000 nM
Compound 4 ended at the assay's limit; the forecaster's own chance of this, stated with the estimate: 25%; at least 2.5-fold (0.39 log units) between middle value and limit.
By their numbers in this assay, from the lowest: compound 2; then compounds 1 and 3 (each within the scatter of the next). At a limit, above all of these: compound 4.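

Compound 4 gives a limit of the assay, not a number: the limit of > 30000 nM in this assay, at which 1 of the 4 values shown sits. Removing the last methyl from the amine nitrogen continues in the direction of the first removal, with an at least 4.6-fold higher number from compound 3 to compound 4 (0.67 log units; beyond the scatter), and removing both methyls gives an at least 65-fold higher number from compound 2 to compound 4 (1.81 log units; beyond the scatter). Aminomethyl in place of acetamido gives an at least 5.4-fold higher number from compound 1 to compound 4 (0.73 log units; beyond the scatter), whereas (methylamino)methyl in that place stayed within the scatter.

As far as these compounds go, how far compound 4 lies past its limit stays open. So does whether an ethyl group or a longer chain on the amine nitrogen would give a lower number than compound 2 460 nM.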